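A few compounds are considered here, and "the series" means these few. Any claim that something is new, unique, unknown or untested is made for them only; others in the source may bear on it.

- Compound 1 `CCOCc1c(C)coc1-c1ccc2c(c1OC)CCCC2(C)C`: 42.7 uM
- Compound 2 `COc1c(-c2occ(C)c2C(=O)O)ccc2c1CCCC2(C)C`: > 61 uM

Both values come from a functional assay on MDA-MB-231 cells (Homo sapiens) for cytotoxicity, read by sulforhodamine B assay, with a stated time of 3 days; on this read-out higher numbers stand for an effect only at larger amounts of compound and lower numbers for an effect already at smaller amounts. Compound 2 gives only a limit, > 61 uM, and not an exact number. Compound 3 `COc1c(-c2occ(C)c2COC(C)=O)ccc2c1CCCC2(C)C` carries acetoxymethyl in place of carboxy on an aromatic carbon. Within the data shown here, one measured step bears on this place: an at least 1.4-fold higher number from compound 1 to compound 2 (0.15 log units; that floor lies within the scatter). That step brings in the carboxy of compound 2 in place of ethoxymethyl, so removing carboxy may give a modestly lower number in this assay, perhaps none beyond the scatter. The estimate means an expected at least 1.5-fold lower number from compound 2 to compound 3 (0.18 log units; that floor lies within the scatter). The expected value for compound 3 is 40 uM, with an estimated range from 18 uM to 80 uM.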

Compound 3, concentration for half-maximal effect: 55.6 uM
Beside the measured number, compound 3's estimate is 1.4-fold (0.14 log units) below it; the range from low to high includes it.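

Putting acetoxymethyl in place of carboxy on this aromatic carbon gives an at least 1.0-fold lower number from compound 2 to compound 3 (0.04 log units; that floor lies within the scatter), so no real drop can be claimed. On these data alone, compound 2 has only a limit, and the true size of that step stays unknown because no exact number exists for it: the limit of > 61 uM in this assay, at which 1 of the 3 values shown sits. Acetyl in place of ethyl on the oxygen gives a 1.3-fold higher number from compound 1 to compound 3 (0.11 log units; within the scatter), so this small swap moves the number no further than repeated measurements would.

The compounds shown leave open whether an amine or a longer chain at this place would bring the effect down to smaller amounts of compound.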